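Swapping a chloro for a methoxy on the pendant phenyl

The compounds below may be only part of what the source reports. "The series", "measured", "known", "first", "only" and "open" are said of these compounds alone.

Among the compounds with values here, compound 3 `CC/C(=C(/c1ccc(/C=C/C(=O)O)cc1)c1cc2ccccc2[nH]1)c1ccc(Cl)cc1` gives 343 nM in a functional assay on MCF7 cells (Homo sapiens) for inhibition (a lower number here means a stronger inhibitor, a higher number a weaker inhibitor), the highest of the three numbers measured so far. Compound 2 `CC/C(=C(/c1ccc(/C=C/C(=O)O)cc1)c1cc2ccccc2[nH]1)c1cccc(OC(F)(F)F)c1` sits nearest with 282 nM. Compound 1 `CC/C(=C(/c1ccc(/C=C/C(=O)O)cc1)c1cc2ccccc2[nH]1)c1cccc(C)c1` gives 140 nM. The step of a 2.5-fold higher number from compound 1 to compound 3 (0.39 log units; beyond the scatter) is modest. Compound 4 `CC/C(=C(/c1ccc(/C=C/C(=O)O)cc1)c1cc2ccccc2[nH]1)c1ccc(OC)cc1` differs from compound 3 by methoxy in place of chloro on an aromatic carbon. Within the data shown here, no measured step exchanges exactly these two groups; the changes that bear on it are those on the same phenyl ring, a 2.5-fold higher number from compound 1 to compound 3 (0.39 log units; beyond the scatter) and a 1.2-fold higher number from compound 2 to compound 3 (0.09 log units; within the scatter), both small. Since such exchanges on this ring have shifted this assay little, the expected step of a 1.3-fold lower number from compound 3 to compound 4 (0.12 log units; within the scatter) is small, probably within the scatter, with no clear direction. Compound 4 is therefore estimated at 260 nM, between 100 nM and 700 nM.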

Compound 4, half-maximal inhibitory concentration: 61 nM
The estimate for compound 4 lay 4.3-fold (0.63 log units) above the measured number; the measured number lies below the stated range.
By their numbers in this assay, from the lowest: compound 4; then compounds 1, 2 and 3 (each within the scatter of the next, the first and the last beyond it).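

On this phenyl ring, the group para to a large group matters more than the first three compounds suggested: methoxy in place of chloro gives a 5.6-fold lower number from compound 3 to compound 4 (0.75 log units; beyond the scatter) in this assay. The 4-methoxyphenyl group also improves on the other two rings, with a 4.6-fold lower number from compound 2 to compound 4 (0.66 log units; beyond the scatter) and with a 2.3-fold lower number from compound 1 to compound 4 (0.36 log units; beyond the scatter), leaving compound 4 with the lowest number of the four. No measurement here accounts for this gain. On these data alone, whether a hydroxyl, an amine or a longer ethoxy chain on that same carbon would lower the number further remains open.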